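This account rests on a few compounds, and the source may have more. Where it says the series, first, only, none or still open, it means among the compounds named here.

Going by the values given here, in a functional assay (aorta) with Rattus norvegicus as the target (a higher number here means a weaker inhibitor, a lower number a stronger inhibitor), compound 2 `COc1ccc(NCCCOc2ccc(S(=O)(=O)c3c(C(C)C)cn4ccccc34)cc2)cc1OC` gives 396 nM, the higher of the two numbers measured so far, while compound 1 `COc1ccc(CNCCCOc2ccc(S(=O)(=O)c3c(C(C)C)cn4ccccc34)cc2)cc1OC` gives 13 nM. The next compound is compound 3 `CCN(CC)CCCOc1ccc(S(=O)(=O)c2c(C(C)C)cn3ccccc23)cc1`, and its difference from compound 2 is diethylamino in place of (3,4-dimethoxyphenyl)amino on a saturated chain carbon, three bonds along the chain from an oxygen on an aromatic ring. Among the compounds with values here, only one measured step bears on this change, a 30-fold higher number from compound 1 to compound 2 (1.48 log units; beyond the scatter), which is large and beyond the scatter. It brought in the same 3,4-dimethoxyphenyl group that compound 3 now gives up. Within the data shown here, no measured compound carries diethylamino, so the size remains uncertain, but a sizeable move to a lower number is expected. The estimated change is a 6.6-fold lower number from compound 2 to compound 3 (0.82 log units; beyond the scatter). For compound 3 the expected value is 60 nM, with an estimated range of 12 nM to 300 nM.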

Compound 3, half-maximal inhibitory concentration: 228 nM
The estimate for compound 3 lay 3.8-fold (0.58 log units) below the measured number, and the stated range covers the measured number.
By their numbers in this assay, from the lowest: compound 1; then compounds 3 and 2 (each within the scatter of the next).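

Replacing (3,4-dimethoxyphenyl)amino with diethylamino on this chain carbon gives a 1.7-fold lower number from compound 2 to compound 3 (0.24 log units; within the scatter), so in this assay these two groups cannot be told apart, although diethylamino has no ring and no hydrogen-bond donor. The aromatic ring alone is therefore not enough to set the number at this position: an 18-fold higher number from compound 1 to compound 3 (1.24 log units; beyond the scatter), and among the three compounds only the (3,4-dimethoxybenzyl)amino group of compound 1 gives a low number. No measurement is available that would explain this difference.

The compounds shown leave open how much of the low number of compound 1 rests on the two methoxy groups and how much on the benzyl group itself, which a plain benzylamino group would address. Also open, going by these compounds, is how a longer link between the nitrogen and the ring, as in a 3,4-dimethoxyphenethylamino group, or a cyclic amine such as piperidine would compare.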